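The source may hold more compounds than are shown below. What is called first, only, known or untested is meant among the compounds shown, and "the series" means these compounds.

For the measured compounds named here, compound 1 `COc1ccc(OS(=O)(=O)c2ccc(N3CCN(C)C3=O)cc2)cc1OC` gives 12000 nM in a functional assay on HT-29 cells (Homo sapiens) for antiproliferative activity, read by sulforhodamine B assay, with a stated time of 48 h (on this read-out higher numbers stand for weaker inhibition and lower numbers for stronger inhibition), the only numerical value among the two compounds measured. Compound 2 `COc1ccc(OS(=O)(=O)c2ccc(N3CCN(C)C3=O)cc2)cc1` reaches only the limit > 100000 nM in this assay. The one measured step, an at least 8.3-fold higher number from compound 1 to compound 2 (0.92 log units; beyond the scatter), concerns hydrogen in place of methoxy on an aromatic carbon and ends at a limit, as shown by the limit of > 100000 nM in this assay, at which 1 of the 2 values shown sits. Going by the values given here, compound 3 `CCCN1CCN(c2ccc(S(=O)(=O)Oc3ccc(OC)c(OC)c3)cc2)C1=O` differs from compound 1 by ethyl in place of hydrogen on a saturated chain carbon bound to an amide-type nitrogen in a ring, a change no measured step informs. Compound 3 is therefore expected to stay close, as no change at the digits printed from compound 1 to compound 3 (within the scatter), giving an estimated 12000 nM with a range from 4000 nM to 40000 nM.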

Compound 3, half-maximal inhibitory concentration: 14000 nM
Estimate against measurement, compound 3: 1.2-fold (0.07 log units) below; the measured number falls inside the stated range.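

Going from methyl to propyl on the chain at the amide-type nitrogen gives a 1.2-fold higher number from compound 1 to compound 3 (0.07 log units; within the scatter) in this assay, so at this position the added ethyl leaves the number where it was. For the compounds shown here, the earlier step spoke only to a methoxy on an aromatic carbon, and this is the first reading at this chain. Nothing shown gives a reason for this result.

The compounds shown leave open whether a chain longer than propyl would also leave the number unchanged. They also leave open what an amine or a carboxylic acid at the end of this chain would do.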